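From Tert-Butyl to Methyl on the Aromatic Ring

The compounds below may be only part of what the source reports. "The series", "measured", "known", "first", "only" and "open" are said of these compounds alone.

Measured compounds:
compound 1 `CC(C)(C)c1ccc(CCCN2CC=C(CCC(=O)NO)C2=O)cc1`: 3330 nM
compound 2 `O=C(CCC1=CCN(Cc2ccc(Cl)cc2)C1=O)NO`: 3330 nM

In a functional assay on ACHN cells (Homo sapiens) for inhibition, read by sulforhodamine B assay (on this read-out higher numbers stand for weaker inhibition of growth and lower numbers for stronger inhibition of growth), compound 1 gives 3330 nM and stands level with compound 2 at the digits shown, the two values lying within the scatter of each other. Compound 3 `Cc1ccc(CCCN2CC=C(CCC(=O)NO)C2=O)cc1` has not been measured; it differs from compound 1 in one place: methyl in place of tert-butyl on an aromatic carbon. Going by the values given here, no measured pair shows the effect of this change, so the step of a 1.4-fold higher number from compound 1 to compound 3 (0.13 log units; within the scatter) is expected to be small, leaning toward weaker growth inhibition but hardly beyond the scatter. Compound 3 is therefore expected to give 4500 nM, with a range from 1500 nM to 12000 nM.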

Compound 3, concentration for 50% growth inhibition: 3330 nM
Compound 3: middle estimate off by 1.4-fold (0.13 log units), on the high side; the range from low to high includes it.
By their numbers in this assay, from the lowest: compounds 1, 2 and 3 (each within the scatter of the next).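

In this assay the replacement of tert-butyl by methyl gives no change at the digits printed from compound 1 to compound 3 (within the scatter) and so shows that, at this place on the aromatic ring, going from four heavy atoms to one leaves growth inhibition in place. For this pair, the bulk of the alkyl group is not reflected in the read-out. No measured evidence offers an explanation for this result. Still open, going by these compounds, is whether an amine or a carboxylic acid at this place would leave the value equally unmoved. A bare hydrogen at the same carbon also remains untested among the compounds shown.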